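Boroxarole amides: from isopropyl to 3-cyanophenyl

The source may report more compounds than this note shows. Statements on the series, on what has been measured and on what is new or still open speak of the compounds shown alone.

Measured so far:
compound 1, `CC(C)c1cccc(NC(=O)CCc2cccc3c2B(O)OC3)c1`, 22000 nM in an ADME assay on WI-38 cells (Homo sapiens) for cytotoxicity, read by MTT assay, with a stated time of 72 h; on this read-out lower numbers stand for stronger inhibition and higher numbers for weaker inhibition
compound 2, `O=C(CCc1cccc2c1B(O)OC2)Nc1cccc2ccccc12`, 1200 nM in this assay

Compound 1 stands highest of the two numbers recorded in this assay. Its nearest neighbour is compound 2, whose number is lower by a margin well beyond the scatter of repeated measurements. No pair of these compounds differs in one place alone, so the gap between compound 1 and compound 2 can only be read as a whole: the naphthyl amide of compound 2 gives the lower number, the isopropylphenyl amide of compound 1 the higher one.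

Compound 3, `N#Cc1cccc(-c2cccc(NC(=O)CCc3cccc4c3B(O)OC4)c2)c1`, has not yet been measured in this assay. It differs from compound 1 in one place: 3-cyanophenyl in place of isopropyl on an aromatic carbon. Among the measured compounds shown here, the change enlarges the aryl amide with a second aromatic ring, which on the two numbers so far accompanies a lower read-out. Compound 3 is therefore expected to move downward by a 6.3-fold lower number from compound 1 to compound 3 (0.80 log units; beyond the scatter), a step beyond the scatter. The estimate for compound 3 is 3500 nM, with a range from 900 nM to 14000 nM.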

Compound 3, half-maximal inhibitory concentration: 7300 nM
For compound 3 the middle estimate is 2.1-fold (0.32 log units) below the measured one, and the stated range covers the measured number.
By their numbers in this assay, from the lowest: compound 2; then compound 3; then compound 1.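

Among the compounds shown here, replacing isopropyl with 3-cyanophenyl on this aromatic carbon gives the first change in one place alone in this assay, and the step is a 3.0-fold lower number from compound 1 to compound 3 (0.48 log units; beyond the scatter), which is modest but beyond the scatter. It shows that the read-out responds to the group at this position, meta to a large group, with the rest of compound 1 held fixed, whereas the gap between compound 1 and compound 2 could be read only as a whole. For the compounds shown here, nothing at hand explains this step, and the one change brings in a six-membered aromatic ring and a nitrile together, so the result cannot be assigned to either part.

The compounds shown leave open whether a plain phenyl group with no nitrile, or a phenyl group carrying an amine or a carboxylic acid instead, would give a similar step at this position. They also leave open how the number would respond to a shorter or longer chain between the amide carbonyl and the shared core.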